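A few compounds are considered here, and "the series" means these few. Any claim that something is new, unique, unknown or untested is made for them only; others in the source may bear on it.

Compound 1 `COc1ccc2nc(-c3ccc(N/C=C\C(=O)c4ccc(OC)c(O)c4)c(C)c3)sc2c1` and compound 2 `COc1ccc2nc(-c3ccc(N/C=C\C(=O)c4ccc(OC)c(O)c4)cc3)sc2c1` share one core; compound 1 differs from compound 2 by methyl in place of hydrogen on an aromatic carbon. In a functional assay on MIA PaCa-2 cells (Homo sapiens) for antiproliferative activity, read by sulforhodamine B assay, with a stated time of 48 h (on this read-out lower numbers stand for stronger inhibition and higher numbers for weaker inhibition), compound 1 gives 17000 nM, and compound 2 gives 21900 nM, so the change made a 1.3-fold lower number from compound 2 to compound 1 (0.11 log units; within the scatter). Compound 3 `COc1ccc2nc(-c3ccc(N/C=C\C(=O)c4cc(OC)c(OC)c([N+](=O)[O-])c4)cc3)sc2c1` is built on another core, and the difference between the two cores is not broken down here. In this assay compound 3 gives 25600 nM. Compound 4 `COc1ccc2nc(-c3ccc(N/C=C\C(=O)c4cc(OC)c(OC)c([N+](=O)[O-])c4)c(C)c3)sc2c1` differs from compound 3 by methyl in place of hydrogen on an aromatic carbon. This is the same kind of change as before, though here the place is meta to a 6-methoxy-1,3-benzothiazol-2-yl group rather than meta to a large group. Because the first change made a 1.3-fold lower number from compound 2 to compound 1 (0.11 log units; within the scatter), the step of a 1.3-fold lower number from compound 3 to compound 4 (0.11 log units; within the scatter) is expected to be of similar size. Compound 4 is therefore estimated at 20000 nM, most likely between 10000 nM and 40000 nM.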

Compound 4, half-maximal inhibitory concentration: 12000 nM
The estimate for compound 4 lay 1.7-fold (0.22 log units) above the measured number; low and high end bracket the measured number.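

In this assay, methyl in place of hydrogen gave a 2.1-fold lower number from compound 3 to compound 4 (0.33 log units; beyond the scatter). Set beside the earlier step, the change carried over from one core to the other with no difference in size that stands out from the noise: the same change on two cores in this assay, a 1.3-fold lower number (0.11 log units; within the scatter) from compound 2 to compound 1 and a 2.1-fold lower number (0.33 log units; beyond the scatter) from compound 3 to compound 4, 1.7-fold (0.22 log units) apart, within the scatter of two such steps. Going by these compounds alone, only this second step lies beyond the scatter on its own, and two pairs cannot show that the change will behave the same way on further cores, nor do they explain why the numbers move.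

The compounds shown leave open what a longer chain such as ethyl, or an amine, would do in place of the methyl at this position. They also leave open whether the methyl step holds on cores beyond these two.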